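Swapping fluoro for cyano on a second core

A few compounds are considered here, and "the series" means these few. Any claim that something is new, unique, unknown or untested is made for them only; others in the source may bear on it.

Measured so far in an ADME assay on CHO cells (Cricetulus griseus) for inhibition, read by MTT assay; on this read-out lower numbers stand for stronger inhibition and higher numbers for weaker inhibition:
compound 1, `CCN(CC)Cc1cc(C)cc(Nc2nc3ccccc3n2Cc2ccc(C#N)cc2)c1O`, gives 14200 nM
compound 2, `CCN(CC)Cc1cc(C)cc(Nc2nc3ccccc3n2Cc2ccc(F)cc2)c1O`, gives 18700 nM
compound 3, `CCN(CC)Cc1cc(Nc2nc3ccccc3n2Cc2ccc(F)cc2)ccc1O`, gives 12000 nM

Compound 1 and compound 2 share one core and differ by cyano in place of fluoro on an aromatic carbon. That change gave a 1.3-fold lower number from compound 2 to compound 1 (0.12 log units; within the scatter). Compound 3 carries a different core; the difference between the two cores is not broken down here, and its value sits close to both others, within the scatter of each.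

Compound 4, `CCN(CC)Cc1cc(Nc2nc3ccccc3n2Cc2ccc(C#N)cc2)ccc1O`, is not yet measured. It differs from compound 3 by cyano in place of fluoro on an aromatic carbon, the same change at the same kind of place as from compound 2 to compound 1. Because that earlier step was a 1.3-fold lower number from compound 2 to compound 1 (0.12 log units; within the scatter), compound 4 is expected to show a 1.3-fold lower number from compound 3 to compound 4 (0.12 log units; within the scatter) in this assay. The estimate for compound 4 is 9200 nM, spanning 5000 nM to 18000 nM.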

Compound 4, half-maximal inhibitory concentration: > 50000 nM
Compound 4: no number, only a limit; the forecaster's own chance of this, stated with the estimate: 5%; middle value at least 5.4-fold (0.73 log units) from the limit.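

In this assay compound 4 gives > 50000 nM, which is a limit of the assay and not a number: the limit of > 50000 nM in this assay, at which 1 of the 4 values shown sits.

On the core of compound 3, cyano in place of fluoro gave an at least 4.1-fold higher number from compound 3 to compound 4 (0.61 log units; beyond the scatter), so the step seen on the core of compound 1 and compound 2 did not carry over: the same change on two cores in this assay, a 1.3-fold lower number (0.12 log units; within the scatter) from compound 2 to compound 1 and an at least 4.1-fold higher number (0.61 log units; beyond the scatter) from compound 3 to compound 4, at least 5.4-fold (0.73 log units) apart, beyond the scatter of two such steps

This shows that, in these two pairs, the outcome of the same change depends on the core, but it does not show which difference between the cores is responsible.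

The compounds shown leave open whether a chloro or a methoxy group in the same place would follow fluoro or cyano on each core.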